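Dropping the chloro: a single-atom change on a chalcone

The compounds below may be only part of what the source reports. "The series", "measured", "known", "first", "only" and "open" are said of these compounds alone.

Measured compounds:
compound 1 `COc1cc(/C=C/C(=O)c2cccc(-n3cc(-c4ccc(Cl)cc4)[nH]c3=O)c2)cc(OC)c1OC` gives 1740 nM
compound 2 `O=C(/C=C/c1cccc(O)c1)c1cccc(-n2cc(-c3ccc(Cl)cc3)[nH]c2=O)c1` gives 1270 nM

Both numbers come from a functional assay on MCF7 cells (Homo sapiens) for inhibition; on this read-out lower numbers stand for stronger inhibition of growth and higher numbers for weaker inhibition of growth. Compound 1 has the larger of the two numbers, but its gap to compound 2 lies within the usual scatter, so the two cannot be told apart. Compound 3 `COc1cc(/C=C/C(=O)c2cccc(-n3cc(-c4ccccc4)[nH]c3=O)c2)cc(OC)c1OC` differs from compound 1 in one place only: hydrogen in place of chloro on an aromatic carbon. Within the data shown here, no measured pair shows this change, so nothing here tells its size. With only one atom removed, the step is expected to be small, about a 1.1-fold higher number from compound 1 to compound 3 (0.06 log units; within the scatter), in either direction within the scatter. Compound 3 is therefore estimated at 2000 nM, between 900 nM and 5000 nM.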

Compound 3, concentration for 50% growth inhibition: 310 nM
The estimate for compound 3 lay 6.5-fold (0.81 log units) above the measured number, outside the stated range (below it).
By their numbers in this assay, from the lowest: compound 3; then compounds 2 and 1 (each within the scatter of the next).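

In this assay, the chloro turns out to matter: changing 4-chlorophenyl to phenyl gives a 5.6-fold lower number from compound 1 to compound 3 (0.75 log units; beyond the scatter), a step beyond the scatter and so a real gain in inhibition of growth from the loss of one heavy atom. Nothing at hand explains why this single atom counts for so much.

On these data alone, whether the same change would act alike on compound 2, with its different other end, stays open. So does how a fluoro or an amine on this same aromatic carbon would compare with hydrogen.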